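From nitro to bromine at the edge of the cytotoxicity limit

A few compounds are considered here, and "the series" means these few. Any claim that something is new, unique, unknown or untested is made for them only; others in the source may bear on it.

Compound 1 `O=C(/C=C\c1ccccc1[N+](=O)[O-])N1N=C(c2ccncc2)OC1c1c[nH]c2ccccc12`: > 30 ug/mL in an ADME assay on HeLa cells (Homo sapiens) for cytotoxicity, read by MTT assay, with a stated time of 72 h (on this read-out higher numbers stand for weaker inhibition of growth and lower numbers for stronger inhibition of growth), a limit of the assay rather than a number.
Compound 2 `O=C(/C=C\c1ccccc1Cl)N1N=C(c2ccncc2)OC1c1c[nH]c2ccccc12`: > 30 ug/mL in this assay, again only a limit.
Compound 3 `O=C(/C=C\c1ccc(Cl)cc1Cl)N1N=C(c2ccncc2)OC1c1c[nH]c2ccccc12`: 29.3 ug/mL in this assay.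

Compound 1 therefore stands only at a limit, and the limit of > 30 ug/mL in this assay, at which 2 of the 3 values shown sit, marks where most of the set sits. The change to compound 4 `O=C(/C=C\c1cccc(Br)c1)N1N=C(c2ccncc2)OC1c1c[nH]c2ccccc12` is 3-bromophenyl in place of 2-nitrophenyl on a double-bonded chain carbon bound to a double-bonded chain carbon. The nearest measured steps are a step that the two limits leave unreadable from compound 1 to compound 2, an at least 1.0-fold lower number from compound 1 to compound 3 (0.01 log units; that floor lies within the scatter) and an at least 1.0-fold lower number from compound 2 to compound 3 (0.01 log units; that floor lies within the scatter), none of which shows a shift beyond the scatter. A step of a number no higher from compound 1 to compound 4 (the limit leaves the size open) is thus expected, meaning essentially none. Compound 4 is estimated at 30 ug/mL, between 18 ug/mL and 50 ug/mL, quite possibly reported only as a limit.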

Compound 4, concentration for 50% growth inhibition: > 30 ug/mL
Compound 4: a limit, no number; the forecaster's own chance of this, stated with the estimate: 65%; the middle value sits exactly at the limit.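

With 3-bromophenyl in place of 2-nitrophenyl, compound 4 gives > 30 ug/mL in this assay, again a limit and not a number. The steps joining it to compound 1 and compound 2 link two limits and cannot be read, and the only readable one is an at least 1.0-fold higher number from compound 3 to compound 4 (0.01 log units; that floor lies within the scatter). A third kind of group on this phenyl ring thus gives no sign of stronger growth inhibition, and the set stays at its ceiling: the limit of > 30 ug/mL in this assay, at which 3 of the 4 values shown sit.

Going by these compounds, how far these compounds lie past the limit stays open. So does whether an amine or a carboxylic acid on this phenyl ring would bring the number clearly under it.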